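Nitro for methyl on the benzyl ether arm

The compounds below may be only part of what the source reports. "The series", "measured", "known", "first", "only" and "open" are said of these compounds alone.

Compound 3 `COc1cccc(OC)c1OCCNCCOc1ccccc1OCc1cccc(C)c1` gives 12000 nM in a functional assay on PC-3 cells (Homo sapiens) for cytotoxicity, read by sulforhodamine B assay (on this read-out higher numbers stand for weaker inhibition of growth and lower numbers for stronger inhibition of growth), the highest of the three numbers in this set. Compound 2 `COc1cccc(OC)c1OCCNCCOc1ccccc1OCc1ccccc1C` gives 11500 nM, and a 1.0-fold higher number from compound 2 to compound 3 (0.02 log units; within the scatter). Compound 1 `COc1cccc(OC)c1OCCNCCOc1ccccc1OCc1ccc(Cl)cc1` gives 2400 nM; from it, a 4.8-fold higher number from compound 1 to compound 2 (0.68 log units; beyond the scatter) and a 5.0-fold higher number from compound 1 to compound 3 (0.70 log units; beyond the scatter). Compound 4 `COc1cccc(OC)c1OCCNCCOc1ccccc1OCc1cccc([N+](=O)[O-])c1` differs from compound 3 by nitro in place of methyl on an aromatic carbon. For the measured compounds named here, no measured step exchanges a methyl for a nitro; the two steps beyond the scatter concern the chloro-to-methyl exchange, and the step within the scatter concerns only the place of the methyl, so none bears directly on this change. The step in this assay is therefore expected to stay within the scatter, in either direction. Compound 4 is estimated at 10000 nM, range 4000 nM to 30000 nM, which means an expected 1.2-fold lower number from compound 3 to compound 4 (0.08 log units; within the scatter).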

Compound 4, concentration for 50% growth inhibition: 13200 nM
Beside the measured number, compound 4's estimate is 1.3-fold (0.12 log units) below it, and the stated range covers the measured number.
By their numbers in this assay, from the lowest: compound 1; then compounds 2, 3 and 4 (each within the scatter of the next).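

In this assay, nitro and methyl on the 3-substituted benzyl arm give values within the scatter of each other (a 1.1-fold higher number from compound 3 to compound 4 (0.04 log units; within the scatter)), and the same holds for the 3-nitrophenyl compound against the 2-methylphenyl compound (a 1.1-fold higher number from compound 2 to compound 4 (0.06 log units; within the scatter)). Only the 4-chlorophenyl compound stands apart (a 5.5-fold higher number from compound 1 to compound 4 (0.74 log units; beyond the scatter)), so compound 1 remains alone in this set, and no data bearing on the reason are available.

The compounds shown leave open whether the gap to compound 1 follows the chlorine itself or its place on the ring. They also leave open how an amine or a carboxylic acid in place of the nitro would read.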